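Cytotoxicity notes on a biaryl amide series

The compounds below may be only part of what the source reports. "The series", "measured", "known", "first", "only" and "open" are said of these compounds alone.

Compound 1 `CCOC(=O)CCCCCOc1cccc(CN(C(=O)c2ccc(-c3cccc(OC(C)C)c3)cc2)C(C)C)c1`: in an ADME assay on HEK293 cells (Homo sapiens) for cytotoxicity, read by CellTiter-Glo and resazurin assay, with a stated time of 72 h (a higher number here means that more compound is needed for the effect, a lower number that less compound is needed), compound 1 gives > 26000 nM, a limit of the assay.
Compound 2 `CCOC(=O)CCCCCOc1cccc(CN(C(=O)c2ccc(-c3ccco3)cc2)C(C)C)c1`: compound 2 gives > 26000 nM, a limit.
Compound 3 `CCOC(=O)CCCCCOc1cccc(CN(C(=O)c2ccc(-c3cccc(OCC)c3)cc2)C(C)C)c1`: compound 3 gives > 22300 nM, a limit.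

Compound 3 thus stands only at a limit, as do the two other values shown; see the limit of > 22300 nM in this assay, at which 1 of the 3 values shown sits, and (the limit of > 26000 nM in this assay, at which 2 of the 3 values shown sit). The steps a step that the two limits leave unreadable from compound 1 to compound 2, a step that the two limits leave unreadable from compound 1 to compound 3 and a step that the two limits leave unreadable from compound 2 to compound 3 are unreadable: the limits hide their size. Compound 4 `CCOC(=O)CCCCCOc1cccc(CN(C(=O)c2ccc(-c3cc(F)cc(OC)c3)cc2)C(C)C)c1` differs from compound 3 by 3-fluoro-5-methoxyphenyl in place of 3-ethoxyphenyl on an aromatic carbon. Within the data shown here, no measured step bears readably on this change, so no step beyond the scatter is expected in this assay, and a further limit seems the likeliest outcome. Compound 4 is therefore expected to give 30000 nM, with a range from 10000 nM to 100000 nM. The step this estimate means is a step that the limit leaves unreadable from compound 3 to compound 4.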

Compound 4, half-maximal effective concentration: > 26000 nM
Compound 4 gave a limit, no number; the forecaster's own chance of this, stated with the estimate: 85%; the middle value does not contradict the limit.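

Compound 4 stands only at a limit, as do compound 1, compound 2 and compound 3, so none of its steps to them can be read. The compounds shown leave open what concentration of any of them gives the half-maximal effect in this assay.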